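From Amino to Methylamino on the Shared Core

The source may report more compounds than this note shows. Statements on the series, on what has been measured and on what is new or still open speak of the compounds shown alone.

For the measured compounds named here, in a functional assay on the whole organism with Rattus norvegicus as the target (on this read-out lower numbers stand for an effect already at smaller amounts and higher numbers for an effect only at larger amounts of compound), compound 3 `CCOC(=O)C(=O)Nc1cccc(N)c1C#N` gives 0.05 mg/kg, the lowest number of the three measured so far. Compound 1 `CCOC(=O)C(=O)Nc1cccc(N(C)C)c1C#N` gives 0.2 mg/kg, and compound 2 `CCOC(=O)C(=O)Nc1cccc(OC)c1C#N` gives 5.3 mg/kg. Compound 4 `CCOC(=O)C(=O)Nc1cccc(NC)c1C#N` changes amino to methylamino, with methyl in place of hydrogen on a nitrogen on an aromatic ring. The closest measured change is a 4.0-fold lower number from compound 1 to compound 3 (0.60 log units; beyond the scatter), with amino in place of dimethylamino, and compound 4 stands structurally between those two. The much larger a 110-fold lower number from compound 2 to compound 3 (2.03 log units; beyond the scatter) replaces methoxy and bears less directly. A small rise in this assay is therefore expected, smaller than the step from dimethylamino and near the scatter, with an estimated 2.0-fold higher number from compound 3 to compound 4 (0.30 log units; within the scatter). For compound 4 the estimated value is 0.1 mg/kg, with an expected range of 0.04 mg/kg to 0.25 mg/kg.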

Compound 4, dose for half-maximal effect: 0.2 mg/kg
Estimate against measurement, compound 4: 2.0-fold (0.30 log units) below, and the stated range covers the measured number.
By their numbers in this assay, from the lowest: compound 3; then compounds 1 and 4 (each within the scatter of the next); then compound 2.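

In this assay, a single methyl on the nitrogen is enough to produce the whole rise from the free amino group (a 4.0-fold higher number from compound 3 to compound 4 (0.60 log units; beyond the scatter)), whereas the second methyl leaves the number unchanged (no change at the digits printed from compound 1 to compound 4 (within the scatter)). The methylamino group also keeps nearly all of the advantage of nitrogen over oxygen at this place (a 27-fold lower number from compound 2 to compound 4 (1.42 log units; beyond the scatter)). Nothing available accounts for why only the first methyl counts. On these data alone, it remains open whether an ethyl or acetyl group on this nitrogen would behave like methyl.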